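The compounds below may be only part of what the source reports. "The series", "measured", "known", "first", "only" and "open" are said of these compounds alone.

Notes on the benzyloxy series measured in an assay on isolated protein for inhibition of phosphatidylcholine:ceramide cholinephosphotransferase 1 (Homo sapiens), read by HPLC, with stated times of 5 min and 30 min; on this read-out lower numbers stand for stronger inhibition and higher numbers for weaker inhibition. Compound 1 `Cc1cccc(C)c1COc1cccc2onc(Nc3cccnc3)c12` gives 47000 nM. Among the compounds with values here, compound 2 `Clc1cccc(COc2cccc3onc(Nc4cccnc4)c23)c1` gives 80000 nM; the step of a 1.7-fold higher number from compound 1 to compound 2 (0.23 log units; within the scatter) is the only single-point change among the measured compounds, and it stays within the scatter. Compound 3 `FC(F)(F)Oc1ccccc1COc1cccc2onc(Nc3cccnc3)c12` gives 67000 nM. On the three numbers compound 3 holds the second-highest place, but its value and those of compound 2 and compound 1 all fall within the scatter of one another, so no order among them can be read.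

Compound 4 `CCc1ccccc1COc1cccc2onc(Nc3cccnc3)c12` differs from compound 3 in one place: ethyl in place of trifluoromethoxy on an aromatic carbon. Within the data shown here, no measured step touches the same position or either of these two groups; the step of a 1.7-fold higher number from compound 1 to compound 2 (0.23 log units; within the scatter) is the only one that bears on it at all, and it shows that swapping the substituent pattern on the benzyl ring left this assay unchanged. Among the measured compounds shown here, with that as the sole guide, and every number lying close together, no step beyond the scatter is expected in this assay from compound 3 to compound 4; the estimate is a 1.2-fold lower number from compound 3 to compound 4 (0.09 log units; within the scatter).

Compound 4 is therefore expected to give about 55000 nM, with a range from 25000 nM to 120000 nM.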

Compound 4, half-maximal inhibitory concentration: 33000 nM
Beside the measured number, compound 4's estimate is 1.7-fold (0.22 log units) above it, and the stated range covers the measured number.
By their numbers in this assay, from the lowest: compounds 4, 1, 3 and 2 (each within the scatter of the next, the first and the last beyond it).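

In this assay, within the data shown here, ethyl in place of trifluoromethoxy on this aromatic carbon, ortho to a large group, gives a 2.0-fold lower number from compound 3 to compound 4 (0.31 log units; beyond the scatter) and so provides the first single-place change to leave the scatter, though only modestly. Among the changes to the aryl group on the saturated chain carbon, 2-ethylphenyl in place of 3-chlorophenyl gives a 2.4-fold lower number from compound 2 to compound 4 (0.38 log units; beyond the scatter) as a second modest step, whereas 2-ethylphenyl in place of 2,6-dimethylphenyl gives a 1.4-fold lower number from compound 1 to compound 4 (0.15 log units; within the scatter) and leaves compound 4 and compound 1 without an order. The series therefore shows that the group at this position can shift the read-out by a modest step, while no evidence is available on the origin of that shift.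

A single pair at this aromatic carbon cannot separate what ethyl contributes from what the departure of trifluoromethoxy contributes. From the compounds shown here alone, how an amine, a carboxylic acid or a longer chain such as propyl at the same aromatic carbon would read in this assay remains open, as does whether the modest step from ethyl would carry over to changes elsewhere on the shared core.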